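A few compounds are considered here, and "the series" means these few. Any claim that something is new, unique, unknown or untested is made for them only; others in the source may bear on it.

Compound 1 `CCCCCCCCCC(=O)c1c[nH]cn1`: 5800 nM
Compound 2 `CC(C)CCCCCCC(=O)c1c[nH]cn1`: 7000 nM

Both numbers come from a functional assay on P388 cells (Mus musculus) for cytotoxicity, read by XTT assay, with a stated time of 72 h; on this read-out higher numbers stand for weaker inhibition and lower numbers for stronger inhibition. Compound 2 stands at 7000 nM, within the usual scatter of compound 1, so these two compounds cannot be ranked against each other. The next compound, compound 3 `CCC(C)CCCCCCC(=O)c1c[nH]cn1`, has not yet been measured. It differs from compound 2 by methyl in place of hydrogen on a saturated chain carbon, eight bonds along the chain from a carbonyl carbon, a change that turns isopropyl into sec-butyl. Among the measured compounds shown here, only one measured step bears on this: a 1.2-fold higher number from compound 1 to compound 2 (0.08 log units; within the scatter). That step also altered the saturated chain, and it stayed within the scatter. One step is thin evidence, but it gives no reason to expect a real shift in this assay in either direction. The expected change is a 1.1-fold lower number from compound 2 to compound 3 (0.03 log units; within the scatter). For compound 3 the estimated value is 6500 nM, with an expected range from 3200 nM to 13000 nM.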

Compound 3, half-maximal inhibitory concentration: 5000 nM
The estimate for compound 3 lay 1.3-fold (0.11 log units) above the measured number; measured number inside the range.
By their numbers in this assay, from the lowest: compounds 3, 1 and 2 (each within the scatter of the next).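

In this assay, methyl in place of hydrogen on a saturated chain carbon, eight bonds along the chain from a carbonyl carbon, gives a 1.4-fold lower number from compound 2 to compound 3 (0.15 log units; within the scatter), so turning isopropyl into sec-butyl makes no readable difference. The unbranched chain offers a second comparison, with a 1.2-fold lower number from compound 1 to compound 3 (0.06 log units; within the scatter), and this change, on a saturated chain carbon bound to two saturated chain carbons, also produces no real shift. Branching near the chain end has now been read at more than one carbon without moving the number beyond the scatter, and no measurement here points to a cause for this.

Still open, as far as these compounds go, is whether a much longer chain would shift the number beyond the scatter. The same question stands for a chain ending in an amine or a carboxylic acid.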